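The compounds below may be only part of what the source reports. "The series", "measured", "known", "first", "only" and "open" are said of these compounds alone.

Measured in a functional assay (aorta) for inhibition, with Rattus norvegicus as the target; a higher number here means a weaker inhibitor, a lower number a stronger inhibitor:
- compound 1 `N/N=C(\S)[C@]1(c2cccnc2)CCCC[S+]1[O-]`: > 30000 nM (a limit)
- compound 2 `N#C[C@]1(c2cccnc2)CCCC[S+]1[O-]`: > 30000 nM (a limit)
- compound 3 `[O-][S+]1CCCC[C@]1(CO)c1cccnc1`: > 30000 nM (a limit)

Compound 3 stands at > 30000 nM, and this is a limit, not a number. It has no readable position in the series, and neither has any other measured compound: the limit of > 30000 nM in this assay, at which 3 of the 3 values shown sit.

The next compound is compound 4 `COC(=N)[C@]1(c2cccnc2)CCCC[S+]1[O-]`, which changes the group on the saturated ring carbon of compound 3: a group of 4 heavy atoms (2 carbon, 1 nitrogen, 1 oxygen; no ring) in place of a group of 2 heavy atoms (1 carbon, 1 oxygen; no ring), on a saturated ring carbon. The rest of the shared core stays the same.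

Among the measured compounds shown here, three measured steps bear on this change, since all of them swap the group at that same carbon: a step that the two limits leave unreadable from compound 1 to compound 3, a step that the two limits leave unreadable from compound 2 to compound 3 and a step that the two limits leave unreadable from compound 1 to compound 2. None of them has a size that can be carried over, and none gives a direction. No group measured at this carbon has yet given a number in this assay. The working expectation is therefore no step beyond the scatter, though the data cannot exclude a real gain for the new group.

The expected change is a number no higher from compound 3 to compound 4 (the limit leaves the size open). Compound 4 is estimated at 30000 nM, with an expected range of 10000 nM to 60000 nM.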

Compound 4, concentration for 90% inhibition: > 30000 nM
Compound 4 ended at the assay's limit (the forecaster's own chance of this, stated with the estimate: 80%); the middle value lies on the limit itself.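

In this assay compound 4 gives > 30000 nM, which is a limit, so none of its steps to compound 1, compound 2 or compound 3 can be read: the limit of > 30000 nM in this assay, at which 4 of the 4 values shown sit.

The compounds shown leave open whether any group on this saturated ring carbon gives a readable number in this assay, and how these four groups rank against one another.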